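Adding One Carbon at Two Different Places

A few compounds are considered here, and "the series" means these few. Any claim that something is new, unique, unknown or untested is made for them only; others in the source may bear on it.

Compound 1 `CCCCCCCCCCCCC(C)OC(=O)NC(=O)Nc1c(C(C)C)cccc1C(C)C` gives 46 nM in an assay on microsomes from intestine for inhibition of acyl-CoA:cholesterol acyltransferase (Oryctolagus cuniculus); on this read-out higher numbers stand for weaker inhibition and lower numbers for stronger inhibition. Compound 2 `CCCCCCCCCCCCC(C)(C)OC(=O)NC(=O)Nc1c(C(C)C)cccc1C(C)C` carries methyl in place of hydrogen on a saturated chain carbon bound to an oxygen next to a carbonyl group and two saturated chain carbons and gives 65 nM in this assay, a step of a 1.4-fold higher number from compound 1 to compound 2 (0.15 log units; within the scatter). Compound 3 `CCCCCCCCCCCCCOC(=O)NC(=O)Oc1c(C(C)C)cccc1C(C)C` is built on another core; how the two cores differ is not broken down here. In this assay compound 3 gives 9 nM, the lowest of the three numbers. Compound 4 `CCCCCCCCCCCCCCOC(=O)NC(=O)Oc1c(C(C)C)cccc1C(C)C` carries methyl in place of hydrogen on a saturated chain carbon, ten or more bonds along the chain from an oxygen next to a carbonyl group. This is the same kind of change as in compound 2, not the same one: the methyl enters at a different place on the chain, as the two descriptions of the changes show. Because a 1.4-fold higher number from compound 1 to compound 2 (0.15 log units; within the scatter) stayed within the scatter, a similarly small step is expected, a 1.1-fold higher number from compound 3 to compound 4 (0.05 log units; within the scatter). Compound 4 is thus estimated at 10 nM, expected between 4 nM and 25 nM.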

Compound 4, half-maximal inhibitory concentration: 10 nM
Beside the measured number, compound 4's estimate shows no gap at the digits printed, and the stated range covers the measured number.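

In this assay, methyl in place of hydrogen gives a 1.1-fold higher number from compound 3 to compound 4 (0.05 log units; within the scatter), and setting this beside the earlier step shows no real difference between the two cores: the same change on two cores in this assay, a 1.4-fold higher number (0.15 log units; within the scatter) from compound 1 to compound 2 and a 1.1-fold higher number (0.05 log units; within the scatter) from compound 3 to compound 4, 1.3-fold (0.10 log units) apart, within the scatter of two such steps. On these two cores, then, the added methyl changes the number by no more than the scatter, and this small step carries over from one core to the other. Two pairs cannot show that it would hold on a further core, and as the methyl enters at different places on the chain, the effect of the core cannot be separated from that of the place.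

The compounds shown leave open what larger or different groups would do on this chain. An amine, a carboxylic acid or a phenyl ring in place of hydrogen could give quite another step.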